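Compound 3 to compound 4: nitro for methyl

A few compounds are considered here, and "the series" means these few. Any claim that something is new, unique, unknown or untested is made for them only; others in the source may bear on it.

Measured in a functional assay on Bel-7402 cells (Homo sapiens) for cytotoxicity, read by MTT assay, with a stated time of 72 h (a lower number here means a stronger inhibitor, a higher number a weaker inhibitor), with these values
- compound 1 `C=C1C(=O)[C@@]23C(=O)OC[C@]4(C(=O)CCC(C)(C)[C@H]4C=O)[C@@H]2CC[C@@H]1[C@H]3O` gives 5030 nM
- compound 2 `C=C1C(=O)[C@@]23C(=O)OC[C@]4([C@@H](OC(C)=O)CCC(C)(C)[C@H]4C=O)[C@@H]2CC[C@@H]1[C@H]3O` gives 75400 nM
- compound 3 `C=C1C(=O)[C@@]23C(=O)OC[C@]4(C(=O)CCC(C)(C)[C@H]4C=O)[C@@H]2CC[C@@H]1[C@H]3OC(=O)c1ccc(C)cc1` gives 1540 nM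

Compound 3 holds the lowest of the three numbers, with compound 1 nearest to it. Compound 4 `C=C1C(=O)[C@@]23C(=O)OC[C@]4(C(=O)CCC(C)(C)[C@H]4C=O)[C@@H]2CC[C@@H]1[C@H]3OC(=O)c1ccc([N+](=O)[O-])cc1` has not yet been measured. It differs from compound 3 by one substitution (nitro in place of methyl on an aromatic carbon), which is nitro in place of methyl on an aromatic carbon.

Within the data shown here, only one measured step bears on this change, the modest one on adding the ester a 3.3-fold lower number from compound 1 to compound 3 (0.51 log units; beyond the scatter). That step leaves the group on the ring untested, so the data set neither a size nor a direction. No shift beyond the scatter is therefore expected in this assay. The expected step is a 1.0-fold lower number from compound 3 to compound 4 (0.01 log units; within the scatter). Compound 4 is estimated at 1500 nM, within an expected range from 600 nM to 4000 nM.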

Compound 4, half-maximal inhibitory concentration: 3300 nM
Beside the measured number, compound 4's estimate is 2.2-fold (0.34 log units) below it; the measured number falls inside the stated range.
By their numbers in this assay, from the lowest: compound 3; then compounds 4 and 1 (each within the scatter of the next); then compound 2.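

In this assay, among these compounds, the group on the aromatic ring of the ester does count: the change to nitro gives a 2.1-fold higher number from compound 3 to compound 4 (0.33 log units; beyond the scatter) and this is the first step to test that group. Adding the (4-nitrophenyl)carbonyl group gives a 1.5-fold lower number from compound 1 to compound 4 (0.18 log units; within the scatter) so the ester alone does not secure the step seen with (4-methylphenyl)carbonyl. No measurement given here explains the difference between methyl and nitro.

On these data alone, how an amine, a methoxy group or a carboxylic acid in the same place would read remains open.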